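This account rests on a few compounds, and the source may have more. Where it says the series, first, only, none or still open, it means among the compounds named here.

Measured compounds:
compound 1 `O=C(Nc1cccc(-c2oc3cc(-c4ccc(F)cc4)ccc3c(=O)c2O)c1)c1ccccc1F`, which gives 4410 nM in a functional assay on A549 cells (Homo sapiens) for antiproliferative activity, read by CCK-8 assay, with a stated time of 72 h; a lower number here means a stronger inhibitor, a higher number a weaker inhibitor
compound 2 `O=C(Nc1cccc(-c2oc3cc(-c4ccc(F)cc4)ccc3c(=O)c2O)c1)c1ccc(Cl)cc1`, which gives 10800 nM in this assay

Compound 2 stands highest of the two numbers. Within the data shown here, its nearest neighbour is compound 1, and the single step between them, a 2.4-fold higher number from compound 1 to compound 2 (0.39 log units; beyond the scatter), is a modest one that nevertheless lies beyond the scatter; it exchanged one substituted phenyl ring on the carbonyl carbon for another.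

Compound 3 `O=C(Nc1cccc(-c2oc3cc(-c4ccc(F)cc4)ccc3c(=O)c2O)c1)c1ccc(C(F)(F)F)cc1` has not yet been measured in this assay. It differs from compound 2 in one place: trifluoromethyl in place of chloro on an aromatic carbon. Among the measured compounds shown here, the one measured step that bears on this change is the step just described, since it also altered the group carried on the ring attached to the carbonyl carbon; but no measured pair shows chloro exchanged for trifluoromethyl, so the direction is undetermined. Given that the one related step was modest, the step from compound 2 to compound 3 is expected to be small, a 1.1-fold higher number from compound 2 to compound 3 (0.05 log units; within the scatter), not clearly beyond the scatter. Compound 3 is therefore estimated to give 12000 nM in this assay, within a range from 5000 nM to 30000 nM.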

Compound 3, half-maximal inhibitory concentration: 19400 nM
Compound 3: the middle estimate sits 1.6-fold (0.21 log units) below what was measured, and the stated range covers the measured number.
By their numbers in this assay, from the lowest: compound 1; then compounds 2 and 3 (each within the scatter of the next).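

At the aromatic carbon para to a large group, trifluoromethyl in place of chloro raises the count of heavy atoms from 1 to 4, yet in this assay this exchange gives a 1.8-fold higher number from compound 2 to compound 3 (0.25 log units; within the scatter) and so does not separate the two compounds. The change of the whole ring substituent is clearer, with a 4.4-fold higher number from compound 1 to compound 3 (0.64 log units; beyond the scatter) as the step here. Among these three, compound 1 with its 2-fluorophenyl group gives the lowest number, and both the 4-chlorophenyl and the 4-(trifluoromethyl)phenyl compounds lie beyond the scatter from it. Nothing measured here accounts for these numbers.

The compounds shown leave open whether a group of another kind on the same aromatic carbon, such as an amine, a methoxy group or a carboxylic acid, would move the number away from that of compound 2 and compound 3. They also leave open whether the lower number of compound 1 goes with fluoro itself or with where it sits on the ring, since the pairs here change both together.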